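Adding a second chloro to compound 2

This account rests on a few compounds, and the source may have more. Where it says the series, first, only, none or still open, it means among the compounds named here.

Compound 1 `Oc1ccc(NC(=S)Nc2ccc3[nH]ccc3c2)cc1`; 848000 nM
Compound 2 `Oc1ccc(NC(=S)Nc2ccc3[nH]ccc3c2)cc1Cl`; 447000 nM

In an ADME assay on CHO-K1 cells (Cricetulus griseus) for cytotoxicity, read by MTT assay, with a stated time of 24 h (a higher number here means that more compound is tolerated, a lower number that less compound is tolerated), compound 2 cannot be told apart from compound 1, since their values lie within the usual scatter of each other. Compound 3 `Oc1c(Cl)cc(NC(=S)Nc2ccc3[nH]ccc3c2)cc1Cl` differs from compound 2 by one exchange (chloro in place of hydrogen on an aromatic carbon), ortho to a hydroxy group. Within the data shown here, the one measured step of this kind is a 1.9-fold lower number from compound 1 to compound 2 (0.28 log units; within the scatter), which stays within the scatter. A similar small downward move, or none beyond the scatter, is therefore expected. The expected change is a 1.4-fold lower number from compound 2 to compound 3 (0.13 log units; within the scatter). Compound 3 is estimated at about 330000 nM, with an expected range from 150000 nM to 700000 nM.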

Compound 3, concentration lethal to 50% of the cells: 523000 nM
Beside the measured number, compound 3's estimate is 1.6-fold (0.20 log units) below it; low and high end bracket the measured number.
By their numbers in this assay, from the lowest: compounds 2, 3 and 1 (each within the scatter of the next).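

In this assay, chloro at the position ortho to a hydroxy group and meta to a chloro group gives a 1.2-fold higher number from compound 2 to compound 3 (0.07 log units; within the scatter) and so cannot be told apart from no change. The earlier exchange, a 1.9-fold lower number from compound 1 to compound 2 (0.28 log units; within the scatter), also lies within the scatter, so neither chloro exchange shown gives a readable shift in this assay. No measured evidence here accounts for this result.

From the compounds shown here alone, whether an amine or a carboxylic acid at this same position would also stay within the scatter remains open. The same question stands for a longer chain such as propyl.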